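From Chloro to Trifluoromethoxy: Expecting Little Change

The source may report more compounds than this note shows. Statements on the series, on what has been measured and on what is new or still open speak of the compounds shown alone.

The compounds measured so far in a functional assay on HeLa cells (Homo sapiens) for antiproliferative activity, read by MTT assay, with a stated time of 12 h (a higher number here means a weaker inhibitor, a lower number a stronger inhibitor), are these:
Compound 1, `COc1cc(OC)c2c(=O)cc(/C=C/c3ccncc3)oc2c1`, gives 18800 nM.
Compound 2, `COc1cc(OC)c2c(=O)cc(/C=C/c3ccc(OCC4CC4)cc3)oc2c1`, gives 10900 nM.
Compound 3, `COc1cc(OC)c2c(=O)cc(/C=C/c3ccc(Cl)cc3)oc2c1`, gives 14200 nM.

Compound 3 holds the second highest of the three numbers. Its nearest neighbour is compound 2: a 1.3-fold higher number from compound 2 to compound 3 (0.11 log units; within the scatter). Its furthest is compound 1: a 1.3-fold lower number from compound 1 to compound 3 (0.12 log units; within the scatter). Both gaps lie within the scatter, so the three compounds cannot be told apart in this assay.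

Compound 4, `COc1cc(OC)c2c(=O)cc(/C=C/c3ccc(OC(F)(F)F)cc3)oc2c1`, differs from compound 3 in one place: trifluoromethoxy in place of chloro on an aromatic carbon. Among the compounds with values here, the step that bears most on this is the one from compound 2 to compound 3, which also swapped the group at that same ring position and stayed within the scatter. The step from compound 1 to compound 3 replaced the whole ring and likewise stayed within the scatter. Nothing here points to a real shift, so the expected step of a 1.1-fold lower number from compound 3 to compound 4 (0.04 log units; within the scatter) is none beyond the scatter. Compound 4 is therefore expected to give about 13000 nM, within a range from 6000 nM to 30000 nM.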

Compound 4, half-maximal inhibitory concentration: > 40000 nM
Compound 4 ended at the assay's limit; the forecaster's own chance of this, stated with the estimate: 5%; middle value at least 3.0-fold (0.48 log units) from the limit.
By their numbers in this assay, from the lowest: compounds 2, 3 and 1 (each within the scatter of the next). At a limit, above all of these: compound 4.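

Compound 4 carries a limit of the assay, not a number: the limit of > 40000 nM in this assay, at which 1 of the 4 values shown sits. Even so, both new steps can be read, and a higher number means a weaker inhibitor: trifluoromethoxy in place of chloro gives an at least 2.8-fold higher number from compound 3 to compound 4 (0.44 log units; beyond the scatter), and trifluoromethyl in place of cyclopropylmethyl on the oxygen gives an at least 3.6-fold higher number from compound 2 to compound 4 (0.56 log units; beyond the scatter). So this aromatic carbon is not indifferent to its group, which the swap between cyclopropylmethoxy and chloro could not show, and the second step shows that what is attached to the oxygen matters, even with that oxygen kept.

From the compounds shown here alone, how far compound 4 lies past the limit remains open, and with it the true size of both steps. Also open, going by these compounds, is whether a methoxy group, an amine or a trifluoromethyl group set directly on the ring would match compound 2 and compound 3 or compound 4.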